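This account rests on a few compounds, and the source may have more. Where it says the series, first, only, none or still open, it means among the compounds named here.

Three compounds share one core and differ only in the saturated chain bound to an aromatic carbon. Compound 1 `CC(=O)c1cc(C)c(OCCCCC#N)cc1O` carries a methyl there; in an assay on isolated protein for binding affinity to leukotriene B4 receptor 1 (Homo sapiens), tested at 1 uM (on this read-out higher numbers stand for more inhibition at the one concentration tested (going by the name of the read-out) and lower numbers for less inhibition), compound 1 gives 35%. Compound 2 `CCCc1cc(C(C)=O)c(O)cc1OCCCCC#N` carries a propyl; in this assay compound 2 gives 37%. Compound 3 `CCCCc1cc(C(C)=O)c(O)cc1OCCCCC#N` carries a butyl; in this assay compound 3 gives 13%, the lowest of the three numbers. The step of a number 2 percentage points higher from compound 1 to compound 2 (within the scatter) lies within the scatter, whereas a number 22 percentage points lower from compound 1 to compound 3 (beyond the scatter) and a number 24 percentage points lower from compound 2 to compound 3 (beyond the scatter) both lie beyond it.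

Compound 4 `CCCCCCc1cc(C(C)=O)c(O)cc1OCCCCC#N` is not yet measured. Its difference from compound 3 is ethyl in place of hydrogen on a saturated chain carbon, four bonds along the chain from an aromatic carbon. The measured steps that bear on this are the two chain extensions that lead to compound 3: a number 22 percentage points lower from compound 1 to compound 3 (beyond the scatter) and a number 24 percentage points lower from compound 2 to compound 3 (beyond the scatter), both modest and both downward. Going by the values given here, a further extension of the same chain is therefore expected to lower the number again or to leave it within the scatter; no measured step points upward. Since compound 3 already sits at 13%, the room for a large drop is limited. Compound 4 is estimated at 7%, with a range from 0% to 22%. The step this estimate implies is a number 6 percentage points lower from compound 3 to compound 4 (within the scatter).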

Compound 4, a percentage reported as inhibition, at one concentration (the size of the read-out at that concentration, not a potency): 13%
Compound 4: middle estimate off by 6 percentage points, on the low side; the measured number falls inside the stated range.
By their numbers in this assay, from the lowest: compounds 3 and 4 (each within the scatter of the next); then compounds 1 and 2 (each within the scatter of the next).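

In this assay, ethyl in place of hydrogen, four bonds along the chain from an aromatic carbon, gives no change at the digits printed from compound 3 to compound 4 (within the scatter), so the fall seen on reaching compound 3 does not continue as this chain grows further. Compound 4 stays as far from the two shorter chains as compound 3 does, with a number 24 percentage points lower from compound 2 to compound 4 (beyond the scatter) and a number 22 percentage points lower from compound 1 to compound 4 (beyond the scatter). Among these four compounds, the same ethyl change leaves the number within the scatter on both the shorter and the longer chain, and the only drop beyond the scatter lies at the step to compound 3: the same change on two cores in this assay, a number 2 percentage points higher (within the scatter) from compound 1 to compound 2 and no change at the digits printed (within the scatter) from compound 3 to compound 4, 2 percentage points apart, within the scatter of two such steps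

The compounds shown leave open whether a longer chain, such as octyl, would stay at this level, or whether a chain ending in an amine or a carboxylic acid would give a different number. Going by these compounds, each number is also the size of the read-out at a single concentration, so it remains unknown whether compound 3 and compound 4 would also match in potency.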